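Ether Substituent Variation on a Shared Lactam Core

The source may hold more compounds than are shown below. What is called first, only, known or untested is meant among the compounds shown, and "the series" means these compounds.

Compound 3 `O=C1NCc2c1c1c(c3c2c2ccccc2n3CCO)CCc2cc(OCC3CC3)ccc2-1` carries a cyclopropylmethoxy group on the shared core. Among the measured compounds shown here, in an assay on isolated protein for inhibition of mitogen-activated protein kinase kinase kinase 11 (Homo sapiens), tested at 1 uM (a higher number here means more inhibition at the concentration tested (going by the name of the read-out), a lower number less inhibition), compound 3 gives 32%, the highest of the three numbers measured so far. Compound 1 `O=C1NCc2c1c1c(c3c2c2ccccc2n3CCO)CCc2cc(OC3CCCCC3)ccc2-1`, with a cyclohexyl on the same oxygen, gives 4% in this assay, and compound 2 `N#CCOc1ccc2c(c1)CCc1c-2c2c(c3c4ccccc4n(CCO)c13)CNC2=O`, with a cyanomethoxy group, gives 8%. The two steps that lead to compound 3 are a number 28 percentage points higher from compound 1 to compound 3 (beyond the scatter) and a number 24 percentage points higher from compound 2 to compound 3 (beyond the scatter), while the step between the other two is a number 4 percentage points higher from compound 1 to compound 2 (within the scatter).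

Compound 4 `O=C1NCc2c1c1c(c3c2c2ccccc2n3CCO)CCc2cc(OCc3ccccn3)ccc2-1` differs from compound 3 by pyridin-2-yl in place of cyclopropyl on a saturated chain carbon bound to an oxygen on an aromatic ring. For the measured compounds named here, no measured step covers this exchange directly. What the measured steps show is that the cyclopropylmethoxy reading stands apart from the other two substituents at this place, which sit within the scatter of one another. A further change at this position is therefore expected to fall back toward the lower readings, so a downward step of a number 16 percentage points lower from compound 3 to compound 4 (beyond the scatter) in this assay is expected, modest in size. Compound 4 is estimated at 16% in this assay, with an expected range from 4% to 38%.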

Compound 4, a percentage reported as inhibition, at one concentration (the size of the read-out at that concentration, not a potency): 30%
Estimate against measurement, compound 4: 14 percentage points below; the range from low to high includes it.
By their numbers in this assay, from the lowest: compounds 1 and 2 (each within the scatter of the next); then compounds 4 and 3 (each within the scatter of the next).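

In this assay, pyridin-2-yl in place of cyclopropyl on a saturated chain carbon bound to an oxygen on an aromatic ring gives a number 2 percentage points lower from compound 3 to compound 4 (within the scatter), so the number stays level across this exchange of a three-membered carbon ring for a six-membered aromatic ring with 1 hetero atom. The new group also stands apart from the other two ethers, with a number 22 percentage points higher from compound 2 to compound 4 (beyond the scatter) and a number 26 percentage points higher from compound 1 to compound 4 (beyond the scatter), which means that the high reading of compound 3 is no longer confined to a single substituent. No evidence is available that accounts for these readings.

The compounds shown leave open how a plain phenyl on the same chain carbon, or an amine at the end of a longer chain, would read in this assay. They also leave open whether any group at this place can rise clear of compound 3 and compound 4.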